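The compounds below may be only part of what the source reports. "The series", "measured", "known", "first", "only" and "open" are said of these compounds alone.

Measured in a functional assay on CCRF-CEM cells for antagonist activity at C-X-C chemokine receptor type 4 (Homo sapiens), read by calcium flux, with stated times of 25 min and 90 s; a lower number here means a stronger inhibitor, a higher number a weaker inhibitor:

compound 1, `CN(C[C@H]1Cc2c(cccc2N2CCNC(C)(C)C2)CN1)[C@H]1CCCc2cccnc21`: 33.9 nM
compound 2, `CN(C[C@H]1Cc2c(cccc2N2CCN(c3ncccn3)CC2)CN1)[C@H]1CCCc2cccnc21`: 30.7 nM
compound 3, `CCCN(C[C@H]1Cc2c(cccc2N2CCNCC2)CN1)[C@H]1CCCc2cccnc21`: 32.2 nM

The three numbers lie within the usual scatter of one another, so compound 1 stands level with compound 2 and compound 3; the data give no order among them. Compound 2 carries a pyrimidinyl on the piperazine and compound 3 a propyl in place of the methyl on the side-chain nitrogen, and neither variation moves the number beyond the scatter.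

Compound 4, `CN(C[C@H]1Cc2c(cccc2N2C[C@@H]3C[C@H]2CN3)CN1)[C@H]1CCCc2cccnc21`, has not been measured in this assay. It differs from compound 1 in one place: a group of 7 heavy atoms (5 carbon, 2 nitrogen; 2 five-membered non-aromatic rings with 1 hetero atom each) in place of a group of 8 heavy atoms (6 carbon, 2 nitrogen; one six-membered non-aromatic ring with 2 hetero atoms), on an aromatic carbon. Since the substituent variations in compounds 1, 2 and 3 leave this assay unmoved, no step beyond the scatter is expected here either, in either direction. The expected step is a 1.0-fold higher number from compound 1 to compound 4 (0.01 log units; within the scatter), within the scatter. Compound 4 is estimated at 35 nM, with a range from 12 nM to 100 nM.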

Compound 4, half-maximal inhibitory concentration: 146 nM
Beside the measured number, compound 4's estimate is 4.2-fold (0.62 log units) below it; measured number outside the range, above it.
By their numbers in this assay, from the lowest: compounds 2, 3 and 1 (each within the scatter of the next); then compound 4.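

In this assay, the aromatic-carbon position does not tolerate every cyclic diamine: exchanging the 3,3-dimethylpiperazin-1-yl for the group with 2 five-membered non-aromatic rings gives a 4.3-fold higher number from compound 1 to compound 4 (0.63 log units; beyond the scatter). This is the first single-place step in the series shown, and it arises although both groups have the same counts of hydrogen-bond donors and acceptors and no net charge. No measurement at hand bears on the reason for this step.

On these data alone, it remains open whether the other stereoisomers of the entering group behave like compound 4, and whether a seven-membered homopiperazine or an open-chain aminoethylamino group at this position stays level with compound 1. As far as these compounds go, the same exchange also remains open with a propyl on the side-chain nitrogen, as in compound 3.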